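The source may report more compounds than this note shows. Statements on the series, on what has been measured and on what is new or still open speak of the compounds shown alone.

Measured compounds:

Compound 1, `COc1ccc(-c2nc(C)c(C(=O)CSc3nc(-c4ccc(Cl)c(Cl)c4)c(C#N)c(=O)[nH]3)s2)cc1`, gives 78.4%.
Compound 2, `COc1ccc(-c2nc(C)c(C(=O)CSc3nc(-c4cccc(OC)c4)c(C#N)c(=O)[nH]3)s2)cc1`, gives 43.2%.
Compound 3, `COc1ccc(-c2nc(C)c(C(=O)CSc3nc(-c4ccc(OC)c(OC)c4)c(C#N)c(=O)[nH]3)s2)cc1`, gives 22.2%.

These three compounds share a core and differ only in the aryl group attached to it, and they were tested in a functional assay on U-87MG ATCC cells for antiproliferative activity against U-87 MG (Homo sapiens), read by MTT assay, with a stated time of 48 h, tested at 50 uM; on this read-out lower numbers stand for a stronger effect and higher numbers for a weaker effect at the one concentration tested. Compound 3 has the lowest number of the three, so its effect is the strongest seen: compound 2 stands nearest, with the gap shown by a number 21 percentage points lower from compound 2 to compound 3 (beyond the scatter), and compound 1 is furthest, with the gap shown by a number 56.2 percentage points lower from compound 1 to compound 3 (beyond the scatter).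

Compound 4, `COc1ccc(-c2nc(C)c(C(=O)CSc3nc(-c4cccc(Cl)c4)c(C#N)c(=O)[nH]3)s2)cc1`, has not yet been measured. It differs from compound 3 as follows: 3-chlorophenyl in place of 3,4-dimethoxyphenyl on an aromatic carbon.

Going by the values given here, two measured steps bear on this change. The step of a number 35.2 percentage points lower from compound 1 to compound 2 (beyond the scatter) shows that swapping chlorine-bearing aryl for a single methoxy-bearing aryl lowered the number a great deal, and the step of a number 21 percentage points lower from compound 2 to compound 3 (beyond the scatter) shows that a second methoxy lowered it further. Compound 4 removes both methoxy groups and brings in a chlorine, so the direction of both steps is reversed here. A large rise beyond the scatter is therefore expected, probably landing between the values of compound 2 and compound 1 rather than fully back to compound 1, since compound 4 carries only one chlorine.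

Compound 4 is estimated at 62%, with a range from 42% to 82%, which means an expected step of a number 39.8 percentage points higher from compound 3 to compound 4 (beyond the scatter).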

Compound 4, a percentage reported as activity, at one concentration (the size of the read-out at that concentration, not a potency): 83.4%
The estimate for compound 4 lay 21.4 percentage points below the measured number, outside the stated range (above it).
By their numbers in this assay, from the lowest: compound 3; then compound 2; then compounds 1 and 4 (each within the scatter of the next).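

In this assay, going by these compounds alone, exchanging one methoxy for chloro on the aryl group gives a number 40.2 percentage points higher from compound 2 to compound 4 (beyond the scatter) and this isolates a single swap, which the earlier compounds could not do, since compound 1 and compound 2 differ by more than one group on that ring. Removing one chlorine from 3,4-dichlorophenyl gives a number 5 percentage points higher from compound 1 to compound 4 (within the scatter) and so shows no readable effect of that second chlorine, which means the large step from compound 1 to compound 2 goes with the arrival of methoxy rather than with the loss of a chlorine. Within the data shown here, the full change from 3,4-dimethoxyphenyl to 3-chlorophenyl gives a number 61.2 percentage points higher from compound 3 to compound 4 (beyond the scatter) and confirms that, across these four compounds, the lower numbers go with methoxy on the aryl group and the higher numbers with chlorine, with no compound going against this.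

Still open, going by these compounds, is how the number would move with an amine or a carboxylic acid on this aryl group, or with a longer chain such as ethoxy in place of methoxy. Nothing available here explains why methoxy and chloro give such different numbers.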